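Methyl for amino in a fused pyrimidinone-type core

A few compounds are considered here, and "the series" means these few. Any claim that something is new, unique, unknown or untested is made for them only; others in the source may bear on it.

Compound 1, `COc1ccc(-c2cc3c(c(N)nn3C)c(=O)[nH]2)cc1`, gives 16%. Compound 2, `Cn1nc(N)c2cnc(-c3ccccc3)cc21`, gives 5%. Compound 3, `Cc1cc2nc(N)nc(N)c2c(=O)[nH]1`, gives 3%.

All three were measured in an assay on isolated protein for inhibition of MAP kinase-activated protein kinase 5 (Homo sapiens), read by mobility shift assay, tested at 30 uM; on this read-out lower numbers stand for less inhibition and higher numbers for more inhibition at the one concentration tested (going by the name of the read-out). Compound 3 sits at the low end of the set: its number and that of compound 2 fall within the usual scatter of each other, while compound 1 stands beyond that scatter above both.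

Compound 4, `Cc1nc(N)c2c(=O)[nH]c(C)cc2n1`, differs from compound 3 at one site: methyl in place of amino on an aromatic carbon. The amino that leaves carries a donor and an acceptor; the methyl that enters carries neither, at a carbon between two ring nitrogen atoms.

For the measured compounds named here, no measured pair in this assay shares this change, so the expected step of a number 1 percentage points higher from compound 3 to compound 4 (within the scatter) is estimated to stay within the scatter, in no clear direction. Compound 4 is expected to give about 4%, within 0% to 13%.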

Compound 4, a percentage reported as inhibition, at one concentration (the size of the read-out at that concentration, not a potency): 1%
For compound 4 the middle estimate is 3 percentage points above the measured one, within the range that was stated.
By their numbers in this assay, from the lowest: compounds 4, 3 and 2 (each within the scatter of the next); then compound 1.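

In this assay, methyl in place of amino on an aromatic carbon between two ring nitrogen atoms gives a number 2 percentage points lower from compound 3 to compound 4 (within the scatter) and so stays within the scatter. At this position, then, the amino group with its hydrogen-bond donor and acceptor can be exchanged for methyl without a readable difference, and compound 4 stays at the low end of the set. Nothing at hand accounts for this result.

From the compounds shown here alone, whether a dimethylamino group, a methoxy group or a longer chain at this carbon would give a readable step remains open. So does whether methyl in place of amino would matter on the core of compound 1.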